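The source may report more compounds than this note shows. Statements on the series, on what has been measured and on what is new or still open speak of the compounds shown alone.

Measured compounds:
compound 1 `COc1ncnc2c1c(-c1ccoc1)cn2[C@@H]1O[C@H](CO)[C@@H](O)[C@H]1O` gives 29400 nM in an ADME assay on MRC5 cells (Homo sapiens), read by MTT assay, with a stated time of 72 h; on this read-out lower numbers stand for stronger inhibition and higher numbers for weaker inhibition
compound 2 `Cc1ncnc2c1c(-c1ccoc1)cn2[C@@H]1O[C@H](CO)[C@@H](O)[C@H]1O` gives 98300 nM in this assay
compound 3 `COc1ncnc2c1c(-c1cccs1)cn2[C@@H]1O[C@H](CO)[C@@H](O)[C@H]1O` gives 43200 nM in this assay

Compound 1 and compound 2 differ by one change, (methyl in place of methoxy on an aromatic carbon), and this change produced a 3.3-fold higher number from compound 1 to compound 2 (0.52 log units; beyond the scatter). Compound 1 and compound 3 differ in another place, (thiophen-2-yl in place of furan-3-yl on an aromatic carbon), and that change produced a 1.5-fold higher number from compound 1 to compound 3 (0.17 log units; within the scatter), so on the numbers alone compound 1 and compound 3 cannot be told apart. Compound 3 stands beside compound 2 with a lower number, and that gap is beyond the scatter.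

Compound 4 `Cc1ncnc2c1c(-c1cccs1)cn2[C@@H]1O[C@H](CO)[C@@H](O)[C@H]1O` has not been measured. Its relation to compound 3 is methyl in place of methoxy on an aromatic carbon, the same change that turned compound 1 into compound 2; the two pairs agree word for word in where the change sits, so it is regarded as the same change made on a core that differs from the core of compound 1 by thiophen-2-yl in place of furan-3-yl on an aromatic carbon. The change is seen in only these two pairs, so its size rests on a single measured step. The expectation for compound 4 in this assay is therefore a step of about the size of the earlier one, namely a 3.2-fold higher number from compound 3 to compound 4 (0.51 log units; beyond the scatter), because compound 1 to compound 2 gave a 3.3-fold higher number from compound 1 to compound 2 (0.52 log units; beyond the scatter) and compound 3 starts from 43200 nM. Compound 4 is estimated at 140000 nM, with a likely range from 60000 nM to 320000 nM.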

Compound 4, half-maximal inhibitory concentration: > 100000 nM
Compound 4: only a limit was reported (the forecaster's own chance of this, stated with the estimate: 25%); the middle value lies beyond the limit too.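

In this assay compound 4 gives only a limit of the assay, > 100000 nM, and not a number. Methyl in place of methoxy gives an at least 2.3-fold higher number from compound 3 to compound 4 (0.36 log units; beyond the scatter), so the change moves the number the same way on both cores and, even at its floor, the step on the core of compound 3 lies beyond the scatter, but its true size stays unknown and this does not show that the step carries over at the same size: the same change on two cores in this assay, a 3.3-fold higher number (0.52 log units; beyond the scatter) from compound 1 to compound 2 and an at least 2.3-fold higher number (0.36 log units; beyond the scatter) from compound 3 to compound 4; the limit leaves it open whether they differ Thiophen-2-yl in place of furan-3-yl, read between the two methyl compounds, gives an at least 1.0-fold higher number from compound 2 to compound 4 (0.00 log units; that floor lies within the scatter), a floor that lies within the scatter, so this pair shows neither that the swap matters on the methyl core nor that it behaves as it does on the methoxy core: the same change on two cores in this assay, a 1.5-fold higher number (0.17 log units; within the scatter) from compound 1 to compound 3 and an at least 1.0-fold higher number (0.00 log units; that floor lies within the scatter) from compound 2 to compound 4; the limit leaves it open whether they differ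

The compounds shown leave open how far the change would carry beyond these two cores, since only furan-3-yl and thiophen-2-yl appear at that place and a phenyl ring or a pyridine there remains untested in this account. They also leave open what an amine, a longer chain such as ethoxy or a halogen would do in the place of the methoxy.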